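Trimming the side chain on the aromatic nitrogen: compound 3

A few compounds are considered here, and "the series" means these few. Any claim that something is new, unique, unknown or untested is made for them only; others in the source may bear on it.

Measured compounds:
compound 1 `CC(=O)N1CCC(c2cc3c(-c4ccc(=O)n(C(C)C)c4)ccnc3[nH]2)CC1`, 2.8 uL/min
compound 2 `CC(C)Cn1cc(-c2ccnc3[nH]c(C4CCN(CC(=O)N(C)C)CC4)cc23)ccc1=O`, 6.6 uL/min

These two compounds were tested in an ADME assay on cells (Hepatocyte, Rattus norvegicus) for metabolic stability; on this read-out lower numbers stand for slow clearance and higher numbers for fast clearance. In this assay compound 1 gives 2.8 uL/min, and compound 2 gives 6.6 uL/min, the higher of the two numbers; the gap between them is beyond the usual scatter, so compound 2 is cleared faster than compound 1.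

Compound 3 `CN(C)C(=O)CN1CCC(c2cc3c(-c4ccc(=O)n(C)c4)ccnc3[nH]2)CC1` has not yet been measured. It is made from compound 2 by one change: hydrogen in place of isopropyl on a saturated chain carbon bound to an aromatic nitrogen. Only the group on the aromatic nitrogen changes; the rest of the molecule stays the same.

With a smaller group on that nitrogen, compound 3 is expected to give a lower number than compound 2, a step of a 1.9-fold lower number from compound 2 to compound 3 (0.28 log units; within the scatter), although a result within the scatter would not be surprising. Compound 3 is estimated at 3.5 uL/min, with a range from 1.5 uL/min to 8 uL/min.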

Compound 3, intrinsic clearance in a liver preparation (reported as CLH), per the amount of preparation that the assay uses: < 1 uL/min
Compound 3 gave a limit, no number; the forecaster's own chance of this, stated with the estimate: 10%; middle value at least 3.5-fold (0.54 log units) from the limit.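

In this assay, replacing isobutyl with methyl on the aromatic nitrogen gives an at least 6.6-fold lower number from compound 2 to compound 3 (0.81 log units; beyond the scatter). The two earlier compounds differ in more than one place, so they could not tie any change in clearance to this position; this pair differs only here, and shows that this group alone can shift clearance beyond the usual scatter. Compound 3 gives a limit of the assay rather than a number, so the step has a known minimum but no known full size: the limit of < 1 uL/min in this assay, at which 1 of the 3 values shown sits.

Going by these compounds, only isobutyl and methyl can be compared at this position, so it remains open whether clearance follows chain size in a steady way or changes abruptly. An ethyl or a propyl chain on the same nitrogen would fill that gap, and this single pair does not explain why clearance falls.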